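A few compounds are considered here, and "the series" means these few. Any claim that something is new, unique, unknown or untested is made for them only; others in the source may bear on it.

Working notes on the series, read in a functional assay on HepG2 cells (Homo sapiens) for cytotoxicity, with a stated time of 72 h; on this read-out lower numbers stand for an effect already at smaller amounts and higher numbers for an effect only at larger amounts of compound. Compound 1 (`C=C[C@@](C)(/C=C/c1ccc(O)c(/C=C/C(=O)OCc2ccccc2)c1)CCC=C(C)C`) gives > 52000 nM, which is a limit and not a number. Compound 2 (`CCOC(=O)/C=C/c1cc(/C=C/[C@](C)(/C=C/c2ccc(OC)cc2)CCC=C(C)C)ccc1O`) gives > 52000 nM, also a limit. Compound 3 (`COc1ccc(/C=C/[C@@](C)(/C=C/c2ccc(O)c(/C=C/C(=O)OC(C)(C)C)c2)CCC=C(C)C)cc1`) gives > 52000 nM, again a limit, so it has no number of its own and stands with the other two: the limit of > 52000 nM in this assay, at which 3 of the 3 values shown sit.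

The change to compound 4 (`COc1ccc(/C=C/[C@@](C)(/C=C/c2ccc(O)c(/C=C/C(=O)OCc3ccccc3)c2)CCC=C(C)C)cc1`) is benzyl in place of tert-butyl on an oxygen next to a carbonyl group. Going by the values given here, the one measured step at this place is a step that the two limits leave unreadable from compound 2 to compound 3, and its size gives no guide. Compound 1 also carries benzyl on an oxygen next to a carbonyl group, and its > 52000 nM is a limit as well.

No step beyond the scatter is expected, in either direction, and the expected step is a step that the limit leaves unreadable from compound 3 to compound 4. Another limit is the most likely report. The estimate for compound 4 is 60000 nM, with an expected range of 30000 nM to 100000 nM.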

Compound 4, half-maximal effective concentration: > 26000 nM
Compound 4: no number, only a limit; the forecaster's own chance of this, stated with the estimate: 85%; the middle value is on the limit's open side.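

In this assay compound 4 gives > 26000 nM, which is a limit and not a number. The steps to compound 4 from compound 1, compound 2 and compound 3 cannot be read, as each pair holds only limits. The compounds shown leave open whether benzyl in place of tert-butyl changes this read-out at all.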